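The source may hold more compounds than are shown below. What is called first, only, known or untested is meant among the compounds shown, and "the series" means these compounds.

In a functional assay on HeLa cells (Homo sapiens) for antiproliferative activity, read by cell counting, with a stated time of 3 days (a lower number here means a stronger inhibitor, a higher number a weaker inhibitor), the measured compounds are:

Compound 1 `CC(=O)c1ccc(Oc2ccccc2NC(C)=C2C(=O)CC(c3ccccc3)CC2=O)cc1` at 130 nM
Compound 2 `CC(Nc1ccccc1Oc1ccccc1)=C1C(=O)CC(c2ccccc2)CC1=O` at 79 nM
Compound 3 `CC(Nc1ccccc1Oc1ccc(C(C)O)cc1)=C1C(=O)CC(c2ccccc2)CC1=O` at 75 nM

Compound 3 at 75 nM stands level with the other two, as a 1.1-fold lower number from compound 2 to compound 3 (0.02 log units; within the scatter) and a 1.7-fold lower number from compound 1 to compound 3 (0.24 log units; within the scatter) both show. The move to compound 4 `CCOc1ccccc1NC(C)=C1C(=O)CC(c2ccccc2)CC1=O` is a larger one: ethyl in place of 4-(1-hydroxyethyl)phenyl on an oxygen on an aromatic ring puts ethyl in place of 4-(1-hydroxyethyl)phenyl on an oxygen on an aromatic ring. Besides those two steps, only a 1.6-fold lower number from compound 1 to compound 2 (0.22 log units; within the scatter) bears on it. All three merely exchange acetyl, hydrogen and 1-hydroxyethyl on the aromatic ring that now leaves, and none removes that ring. Within the data shown here, they therefore give no direct measure of this change, and no measured compound lacks the ring. A moderate step to a higher number in this assay is expected, though with wide uncertainty. The estimate amounts to a 3.3-fold higher number from compound 3 to compound 4 (0.52 log units; beyond the scatter) as the expected step. Compound 4 is estimated at 250 nM with an expected range from 70 nM to 1000 nM for a measurement still to come.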

Compound 4, half-maximal inhibitory concentration: 180 nM
Compound 4: middle estimate off by 1.4-fold (0.14 log units), on the high side; low and high end bracket the measured number.
By their numbers in this assay, from the lowest: compounds 3, 2, 1 and 4 (each within the scatter of the next, the first and the last beyond it).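

Among these compounds, compound 4 is the only compound here without an aromatic ring on this oxygen, and in this assay the change to ethyl reads differently depending on the comparison: a 2.4-fold higher number from compound 3 to compound 4 (0.38 log units; beyond the scatter) and a 2.3-fold higher number from compound 2 to compound 4 (0.36 log units; beyond the scatter) lie beyond the scatter, while a 1.4-fold higher number from compound 1 to compound 4 (0.14 log units; within the scatter) stays within it. Removing the ring therefore gives only a modest step, and compound 4 keeps a value of 180 nM with ethoxy in place of the larger groups. Nothing available explains this step.

The compounds shown leave open whether the ring itself matters or whether a propyl chain, a butyl chain, a benzyl group or a cyclohexyl ring on this oxygen would match the phenyl compounds. They also do not show how an amine or a carboxylic acid on the ethyl chain would fare.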